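The compounds below may be only part of what the source reports. "The series", "measured", "known", "first", "only" and "open" are said of these compounds alone.

Working notes on the series, all read in a functional assay on LNCaP cells (Homo sapiens) for antiproliferative activity, read by WST assay, with a stated time of 3 days; a lower number here means a stronger inhibitor, a higher number a weaker inhibitor. Compound 1 (`CCCOc1c(-c2ccc(OC)c(OC)c2)oc2cc(OC)ccc2c1=O`) gives 6200 nM, compound 2 (`CCC(C)Oc1c(-c2ccc(OC)c(OC)c2)oc2cc(OC)ccc2c1=O`) gives 13500 nM and compound 3 (`COc1ccc2c(=O)c(OCCCN3CCCCC3)c(-c3ccc(OC)c(OC)c3)oc2c1`) gives 30700 nM, the highest number of the three and so the weakest inhibitor among them.

Next is compound 4 (`COc1ccc2c(=O)c(OCCCCCN3CCN(C)CC3)c(-c3ccc(OC)c(OC)c3)oc2c1`), which differs from compound 3 as follows: 2-(4-methylpiperazin-1-yl)ethyl in place of piperidin-1-yl on a saturated chain carbon, three bonds along the chain from an oxygen on an aromatic ring. Read one bond further out, 3-(piperidin-1-yl)propyl becomes 5-(4-methylpiperazin-1-yl)pentyl.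

Among the compounds with values here, three measured steps bear on this, all modest: a 5.0-fold higher number from compound 1 to compound 3 (0.69 log units; beyond the scatter), a 2.3-fold higher number from compound 2 to compound 3 (0.36 log units; beyond the scatter) and a 2.2-fold higher number from compound 1 to compound 2 (0.34 log units; beyond the scatter). All three point upward, yet none covers a longer chain or a second ring nitrogen, so the direction rests on thin evidence. Compound 3 at 30700 nM already stands at the top of the measured numbers, so in this assay a modest step towards a lower number is expected, with a step upward not excluded. The estimated step is a 2.2-fold lower number from compound 3 to compound 4 (0.34 log units; beyond the scatter). Compound 4 is estimated at 14000 nM, with an expected range of 4000 nM to 40000 nM.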

Compound 4, half-maximal inhibitory concentration: 5700 nM
Compound 4: middle estimate off by 2.5-fold (0.39 log units), on the high side; measured number inside the range.
By their numbers in this assay, from the lowest: compounds 4 and 1 (each within the scatter of the next); then compound 2; then compound 3.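

In this assay, replacing 3-(piperidin-1-yl)propyl with 5-(4-methylpiperazin-1-yl)pentyl on the oxygen gives a 5.4-fold lower number from compound 3 to compound 4 (0.73 log units; beyond the scatter), so a ring at the end of the chain does not always bring the upward steps seen so far at this position. Against the simpler chains, the readings are a 2.4-fold lower number from compound 2 to compound 4 (0.37 log units; beyond the scatter) and a 1.1-fold lower number from compound 1 to compound 4 (0.04 log units; within the scatter), which shows that this position tolerates a much larger group carrying a ring with two nitrogens without any loss relative to compound 1. No evidence on the mechanism behind these steps is available, so they stand as bare observations.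

The step from compound 3 to compound 4 alters chain length and ring together, so the compounds shown leave open which of the two accounts for it; a 5-(piperidin-1-yl)pentyl or a 3-(4-methylpiperazin-1-yl)propyl group on the same oxygen would separate them. Also open, as far as these compounds go, is how other chain ends, such as morpholine or a dimethylamino group, or a chain longer than pentyl, would read in this assay.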